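This account rests on a few compounds, and the source may have more. Where it says the series, first, only, none or still open, it means among the compounds named here.

Measured so far in an ADME assay on Vero cells (Chlorocebus sabaeus) for cytotoxicity, with a stated time of 5 days; a lower number here means a stronger inhibitor, a higher number a weaker inhibitor:
Compound 1 `[N-]=[N+]=N[C@H]1C[C@H](n2cnc3c(NCCO)nc(N)nc32)O[C@@H]1CO` gives > 100000 nM in this assay; this is a limit of the assay, not a number.
Compound 2 `COc1nc(NC2CC2)c2ncn([C@H]3C[C@H](N=[N+]=[N-])[C@@H](CO)O3)c2n1` gives > 100000 nM in this assay; again only a limit.
Compound 3 `CN(C)c1nc(Cl)nc2c1ncn2[C@H]1C[C@H](N=[N+]=[N-])[C@@H](CO)O1` gives > 100000 nM in this assay; again only a limit.

Compound 1 therefore stands where every measured compound stands: nothing more than a limit is known for it, and the three results agree in sitting at the limit of > 100000 nM in this assay, at which 3 of the 3 values shown sit. Among the compounds with values here, no compound among the three has been measured beside a close relative, so no measured step can say how a single change moves this read-out.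

Compound 4 `C=CCNc1nc(N)nc2c1ncn2[C@H]1C[C@H](N=[N+]=[N-])[C@@H](CO)O1` is the next to be tested. It differs from compound 1 in one place: vinyl in place of hydroxymethyl on a saturated chain carbon bound to a nitrogen on an aromatic ring. The change exchanges a small polar group for a small unsaturated one on the same chain carbon bound to the ring nitrogen.

With every measured value at the limit, the step from compound 1 to compound 4 is expected to be none beyond the scatter, a number no higher from compound 1 to compound 4 (the limit leaves the size open). Compound 4 is accordingly estimated at 100000 nM, within 50000 nM to 300000 nM, most likely again reported only as a limit.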

Compound 4, half-maximal inhibitory concentration: > 100000 nM
Compound 4 ended at the assay's limit (the forecaster's own chance of this, stated with the estimate: 85%); the middle value sits exactly at the limit.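

In this assay, within the data shown here, compound 1 and compound 4 both give only a limit, not a number, and no step between the two can be read. The compounds shown leave open at what concentration any of them would inhibit these cells, and whether vinyl in place of hydroxymethyl changes that concentration at all.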